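The source may report more compounds than this note shows. Statements on the series, on what has been measured and on what is new or still open speak of the compounds shown alone.

Measured so far:
- Compound 1 `CC1=NN(C(=O)CN2CCCCC2)C(c2ccccc2O)C1` gives 5890 nM in a functional assay on PC-3 cells (Homo sapiens) for cytotoxicity, read by MTT assay, with a stated time of 48 h; on this read-out higher numbers stand for weaker inhibition and lower numbers for stronger inhibition.
- Compound 2 `CC1=NN(C(=O)CN2CCC(c3ccccc3)CC2)C(c2ccccc2O)C1` gives 20400 nM in this assay.

Going by the values given here, compound 1 holds the lower of the two numbers: the only measured step, a 3.5-fold higher number from compound 1 to compound 2 (0.54 log units; beyond the scatter), lies beyond the scatter. Compound 3 `CC1=NN(C(=O)CN2CCN(C)CC2)C(c2ccccc2O)C1` differs from compound 1 by 4-methylpiperazin-1-yl in place of piperidin-1-yl on a saturated chain carbon bound to a carbonyl carbon. Among the compounds with values here, the one step known swaps hydrogen for phenyl on the saturated ring rather than exchanging the ring itself, so it offers little guidance here. The expected step is a 1.2-fold higher number from compound 1 to compound 3 (0.07 log units; within the scatter), meaning no change beyond the scatter. Compound 3 is therefore estimated at 7000 nM, within 3000 nM to 18000 nM.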

Compound 3, half-maximal inhibitory concentration: 11800 nM
Beside the measured number, compound 3's estimate is 1.7-fold (0.23 log units) below it; low and high end bracket the measured number.
By their numbers in this assay, from the lowest: compounds 1, 3 and 2 (each within the scatter of the next, the first and the last beyond it).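

In this assay, 4-methylpiperazin-1-yl in place of piperidin-1-yl on a saturated chain carbon bound to a carbonyl carbon gives a 2.0-fold higher number from compound 1 to compound 3 (0.30 log units; within the scatter). The earlier step only added phenyl to the saturated ring, whereas this one exchanges the ring itself, and a ring with 2 hetero atoms stays within the scatter of the ring with 1 hetero atom. Nothing available accounts for this result.

Still open, from the compounds shown here alone, is how morpholin-4-yl, with a ring oxygen, or an open-chain dimethylamino group would read at this chain carbon.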